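The source may hold more compounds than are shown below. What is called first, only, known or untested is meant among the compounds shown, and "the series" means these compounds.

Measured in a functional assay on HepG2 cells (Homo sapiens) for antiproliferative activity, read by MTT assay, with a stated time of 72 h; a lower number here means a stronger inhibitor, a higher number a weaker inhibitor:
Compound 1 `O=C1C=C(N2CCC(c3ccccc3)CC2)C(=O)c2c(O)cccc21`: 9700 nM
Compound 2 `O=C1C=C(N2CCC(c3ccc(Cl)cc3)CC2)C(=O)c2c(O)cccc21`: 5400 nM

Compound 2 lies within the scatter of compound 1, so the two cannot be ranked. Compound 3 `Cc1ccccc1C1CCN(C2=CC(=O)c3cccc(O)c3C2=O)CC1` has 2-methylphenyl in place of 4-chlorophenyl on a saturated ring carbon. Among the compounds with values here, the only measured step that bears on this is a 1.8-fold lower number from compound 1 to compound 2 (0.25 log units; within the scatter), with chloro in place of hydrogen on an aromatic carbon, and it stays within the scatter. Within the data shown here, no measured compound carries 2-methylphenyl, so this evidence is thin. The expected change is none beyond the scatter, an estimated 1.3-fold higher number from compound 2 to compound 3 (0.11 log units; within the scatter). For compound 3 the expected value is 7000 nM, with an estimated range of 3000 nM to 16000 nM.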

Compound 3, half-maximal inhibitory concentration: 16600 nM
Compound 3: the middle estimate sits 2.4-fold (0.38 log units) below what was measured; the measured number lies above the stated range.
By their numbers in this assay, from the lowest: compounds 2, 1 and 3 (each within the scatter of the next, the first and the last beyond it).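

In this assay, within the data shown here, 2-methylphenyl in place of 4-chlorophenyl on the saturated ring carbon gives the first step in this set that lies beyond the scatter (a 3.1-fold higher number from compound 2 to compound 3 (0.49 log units; beyond the scatter)). Against the unsubstituted phenyl of compound 1, the methyl stays within the scatter (a 1.7-fold higher number from compound 1 to compound 3 (0.23 log units; within the scatter)), so the methyl alone cannot be said to change the number. Nothing shown here accounts for the size of either step.

On these data alone, whether a methoxy group, an amine or a carboxylic acid on that aromatic ring would move the number beyond the scatter from compound 1 stays open.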